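A few compounds are considered here, and "the series" means these few. Any claim that something is new, unique, unknown or untested is made for them only; others in the source may bear on it.

- compound 1 `Cc1ccc(-c2cc(C(=O)N3CCC4(CC3)CC(=O)c3nn(C(C)(C)C)cc3O4)c3ccccc3n2)cc1` 1440 nM
- compound 2 `CC(C)(C)n1cc2c(n1)C(=O)CC1(CCN(C(=O)c3cc(N4CCNCC4)nc4ccccc34)CC1)O2` 8570 nM

In a functional assay on HepG2 cells (Homo sapiens) for inhibition, read by MTT assay, with a stated time of 72 h (a higher number here means a weaker inhibitor, a lower number a stronger inhibitor), compound 2 stands at the high end, with 8570 nM as the higher of the two numbers, so it is the weaker inhibitor of the pair. The change from compound 2 to compound 3 `CCOc1cc(C(=O)N2CCC3(CC2)CC(=O)c2nn(C(C)(C)C)cc2O3)c2ccccc2n1` is ethoxy in place of piperazin-1-yl on an aromatic carbon and it sits next to the ring nitrogen, with ethoxy in place of piperazin-1-yl. Among the compounds with values here, one measured step bears on this place, a 6.0-fold higher number from compound 1 to compound 2 (0.77 log units; beyond the scatter) (modest, and beyond the scatter), where piperazin-1-yl took the place of 4-methylphenyl. Ethoxy itself has no measured example, so the evidence is thin. Compound 1 gives 1440 nM without piperazin-1-yl, so a lower number is expected once that group leaves. The expected change in this assay is a modest one, a 2.9-fold lower number from compound 2 to compound 3 (0.46 log units; beyond the scatter) as estimated, toward a lower number. Compound 3 is estimated at 3000 nM (range 1000 nM to 9000 nM).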

Compound 3, half-maximal inhibitory concentration: > 10000 nM
Compound 3: no number, only a limit; the forecaster's own chance of this, stated with the estimate: 4%; at least 3.3-fold (0.52 log units) between middle value and limit.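

The reading for compound 3 is a limit of the assay and not a number: the limit of > 10000 nM in this assay, at which 1 of the 3 values shown sits.

Even so, ethoxy in place of 4-methylphenyl gives an at least 6.9-fold higher number from compound 1 to compound 3 (0.84 log units; beyond the scatter), so at this position, next to the ring nitrogen, 4-methylphenyl now gives a lower number than both other groups shown. Taking away piperazin-1-yl therefore does not by itself bring the number down towards that of compound 1, and the comparison with piperazin-1-yl, an at least 1.1-fold higher number from compound 2 to compound 3 (0.06 log units; that floor lies within the scatter), does not separate ethoxy from it.

Going by these compounds, the true number for compound 3 remains unknown, so ethoxy and piperazin-1-yl cannot yet be ranked. On these data alone, it also remains open whether the low number of compound 1 needs the methyl of 4-methylphenyl, or would hold with an unsubstituted phenyl ring or an open-chain amine such as dimethylamino.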